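The source may hold more compounds than are shown below. What is called first, only, known or untested is meant among the compounds shown, and "the series" means these compounds.

Of the compounds shown here, two have so far been measured in a functional assay on DU-145 cells (Homo sapiens) for cytotoxicity, read by XTT assay, with a stated time of 24 h; on this read-out higher numbers stand for weaker inhibition and lower numbers for stronger inhibition. Compound 1, `CCOc1cc(C)c(Cl)c2c1C(=O)C=CC2=O`, gives 25400 nM in this assay. Compound 2, `CC(=O)Oc1c(C)cc(Cl)c2c1C(=O)C=CC2=O`, gives 12500 nM in this assay, the lower of the two numbers; the gap to compound 1 lies beyond the usual scatter of repeated measurements, so compound 2 inhibits more strongly than compound 1. Compound 3, `CCOc1c(C)cc(Cl)c2c1C(=O)C=CC2=O`, has not yet been measured. It differs from compound 2 in one place: ethyl in place of acetyl on an oxygen on an aromatic ring The same difference, cut one bond further out, reads acetoxy to ethoxy. Among the measured compounds shown here, no measured pair in this set shows this particular change, so the size of the step rests only on the two numbers in hand. For compound 3 a modest rise in the number, possibly no larger than the scatter, is expected, giving a step of a 1.6-fold higher number from compound 2 to compound 3 (0.20 log units; within the scatter). Compound 3 is accordingly estimated at 20000 nM, with a range from 8000 nM to 50000 nM.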

Compound 3, half-maximal inhibitory concentration: 26200 nM
Compound 3: the middle estimate sits 1.3-fold (0.12 log units) below what was measured; the measured number falls inside the stated range.
By their numbers in this assay, from the lowest: compound 2; then compounds 1 and 3 (each within the scatter of the next).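

In this assay, the acetoxy to ethoxy change gives a 2.1-fold higher number from compound 2 to compound 3 (0.32 log units; beyond the scatter), so the group on this oxygen on an aromatic ring registers in the read-out, with ethyl going with weaker inhibition than acetyl. Compound 1 and compound 2 differ in more than one place, so they could not isolate this change; this pair holds the rest of the core constant and offers a first measure of it. No measurement in hand explains the difference between acetyl and ethyl.

The compounds shown leave open whether other groups on this oxygen, such as a free hydroxyl, a propyl chain or a benzoyl group, would follow acetyl or ethyl. They also leave open whether the step would keep its size if fluorine replaced the chlorine on the core.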